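Propyl for ethyl on a sulfonate ester cytotoxicity series

This account rests on a few compounds, and the source may have more. Where it says the series, first, only, none or still open, it means among the compounds named here.

The study compares four compounds in a functional assay on MCF7 cells (Homo sapiens) for cytotoxicity, read by sulforhodamine B assay, with a stated time of 48 h; on this read-out higher numbers stand for weaker inhibition and lower numbers for stronger inhibition. Compound 1 `CCc1ccccc1NS(=O)(=O)c1cccc(NC(=O)NCCCCl)c1` gives 43000 nM, and compound 2 `CCCc1ccccc1NS(=O)(=O)c1cccc(NC(=O)NCCCCl)c1` gives 18000 nM; the change between them is methyl in place of hydrogen on a saturated chain carbon, two bonds along the chain from an aromatic carbon and it gives a 2.4-fold lower number from compound 1 to compound 2 (0.38 log units; beyond the scatter). Compound 3 `CCNC(=O)Nc1ccc(S(=O)(=O)Oc2ccccc2CC)cc1` gives 3400 nM, the lowest number of the three measured compounds. The difference between the core of compound 1 and the core of compound 3 is not broken down here. Compound 4 `CCCc1ccccc1OS(=O)(=O)c1ccc(NC(=O)NCC)cc1` has not yet been measured; it differs from compound 3 by methyl in place of hydrogen on a saturated chain carbon, two bonds along the chain from an aromatic carbon, which is the same change as that from compound 1 to compound 2. Because compound 2 gave a 2.4-fold lower number from compound 1 to compound 2 (0.38 log units; beyond the scatter), a step of similar size is expected here, namely a 2.3-fold lower number from compound 3 to compound 4 (0.36 log units; beyond the scatter) in this assay. Compound 4 is therefore estimated at 1500 nM, with a range from 600 nM to 4000 nM.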

Compound 4, half-maximal inhibitory concentration: 1300 nM
The estimate for compound 4 lay 1.2-fold (0.06 log units) above the measured number; the range from low to high includes it.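

In this assay, the change from ethyl to propyl on the core of compound 3 gives a 2.6-fold lower number from compound 3 to compound 4 (0.42 log units; beyond the scatter). The step therefore carried over from one core to the other with no difference in size beyond the scatter: the same change on two cores in this assay, a 2.4-fold lower number (0.38 log units; beyond the scatter) from compound 1 to compound 2 and a 2.6-fold lower number (0.42 log units; beyond the scatter) from compound 3 to compound 4, 1.1-fold (0.04 log units) apart, within the scatter of two such steps. Among the compounds shown here, this shows agreement on only two cores in one assay; it does not show that the step would hold on any other core, and it does not explain why the number falls.

The compounds shown leave open whether a longer chain, such as butyl, would lower the number further. They also leave open how a branched isopropyl group or a terminal amine on the chain would compare with propyl.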